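The source may report more compounds than this note shows. Statements on the series, on what has been measured and on what is new or still open speak of the compounds shown alone.

Of the compounds shown here, three built on one shared core have been measured in a functional assay for inhibition, tested at 60 ug/mL; a higher number here means a stronger effect of the compound at the concentration tested, a lower number a weaker effect. Compound 1 `Cc1cc(O)c(C(C)C)cc1-c1cc(-c2ccccc2[N+](=O)[O-])c(C#N)c(=O)[nH]1` gives 31% in this assay. Compound 2 `COc1cc(OC)c(-c2cc(-c3cc(C(C)C)c(O)cc3C)[nH]c(=O)c2C#N)c(OC)c1` gives 66% in this assay. Compound 3 `Cc1cc(O)c(C(C)C)cc1-c1cc(-c2ccccc2Cl)c(C#N)c(=O)[nH]1` gives 26% in this assay. Compound 3 thus stands lowest of the three numbers: its nearest neighbour is compound 1, separated by a gap that lies within the scatter, while compound 2 stands furthest from it, by a gap beyond the scatter.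

For the measured compounds named here, only one measured step touches the position in question: a number 5 percentage points lower from compound 1 to compound 3 (within the scatter). That step exchanged the group on the aromatic ring but kept the ring itself, and it did not move the read-out beyond the scatter.

Compound 4 `Cc1cc(O)c(C(C)C)cc1-c1cc(-c2cccs2)c(C#N)c(=O)[nH]1` is not yet measured. It differs from compound 3 in one place: thiophen-2-yl in place of 2-chlorophenyl on an aromatic carbon. Here the whole ring is exchanged, not merely its substituent, so the single step from compound 1 to compound 3 bears on it only loosely. Going by the values given here, compound 2 carries a quite different aromatic ring at this place and shows a higher number, but no single step links it to compound 3 or compound 4.

On this basis compound 4 is expected to show a number 4 percentage points higher from compound 3 to compound 4 (within the scatter), that is, no step beyond the scatter. The estimate for compound 4 in this assay is 30%, with a range from 15% to 50%.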

Compound 4, a percentage reported as inhibition, at one concentration (the size of the read-out at that concentration, not a potency): 54.3%
Beside the measured number, compound 4's estimate is 24.3 percentage points below it; the measured number lies above the stated range.
By their numbers in this assay, from the lowest: compounds 3 and 1 (each within the scatter of the next); then compound 4; then compound 2.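

In this assay the earlier step at this position changed only the substituent on the phenyl ring and stayed within the scatter, whereas exchanging the whole ring moves the read-out: thiophen-2-yl in place of 2-chlorophenyl gives a number 28.3 percentage points higher from compound 3 to compound 4 (beyond the scatter) and thiophen-2-yl in place of 2-nitrophenyl gives a number 23.3 percentage points higher from compound 1 to compound 4 (beyond the scatter) in the same direction. Two different starting groups thus lead to the same kind of change, so at this aromatic carbon, ortho to a cyano group, the read-out depends on which ring is present and not only on what that ring carries. The data at hand offer no explanation for this rise.

The compounds shown do not separate the exchange of a six-membered ring for a five-membered ring from the presence of sulfur or the loss of the chloro or nitro group, and an unsubstituted phenyl, a furan-2-yl or a thiophen-3-yl at this place would bear on that question. On these data alone, it also remains open whether a substituent on the thiophene ring, such as methyl or chloro, would keep the higher number seen for compound 4.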